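Notes on replacing 4-butylpiperazin-1-yl with piperidin-1-yl

The compounds below may be only part of what the source reports. "The series", "measured", "known", "first", "only" and "open" are said of these compounds alone.

Values so far in a functional assay on MCF7 cells (Homo sapiens) for cytotoxicity, read by MTT assay, with a stated time of 72 h (on this read-out lower numbers stand for stronger inhibition and higher numbers for weaker inhibition), are:
compound 1 `O=C1c2c[n+]([O-])c3ccccc3c2C(=O)c2c1c1ccccc1n2CCCCn1ccnc1` gives 130 nM
compound 2 `O=C1c2c[n+]([O-])c3ccccc3c2C(=O)c2c1c1ccccc1n2CCCCN1CCNCC1` gives 12000 nM
compound 3 `CCCCN1CCN(CCCCn2c3c(c4ccccc42)C(=O)c2c[n+]([O-])c4ccccc4c2C3=O)CC1` gives 6900 nM

Compound 3 stands with compound 2 at the high end of these three numbers, and the two cannot be separated: the step is a 1.7-fold lower number from compound 2 to compound 3 (0.24 log units; within the scatter) and butyl in place of hydrogen on the ring amine nitrogen therefore shows no measurable change. Compound 1 lies far lower, with a 53-fold higher number from compound 1 to compound 3 (1.72 log units; beyond the scatter) and a 92-fold higher number from compound 1 to compound 2 (1.97 log units; beyond the scatter) as the two large steps.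

The next compound is compound 4 `O=C1c2c[n+]([O-])c3ccccc3c2C(=O)c2c1c1ccccc1n2CCCCN1CCCCC1` and the change is piperidin-1-yl in place of 4-butylpiperazin-1-yl on a saturated chain carbon, four bonds along the chain from an aromatic nitrogen with piperidin-1-yl in place of 4-butylpiperazin-1-yl on a saturated chain carbon, four bonds along the chain from an aromatic nitrogen. Going by the values given here, no measured step makes this exact swap. Among the compounds with values here, compound 4 keeps a six-membered non-aromatic ring and lacks the 1H-imidazol-1-yl group of compound 1, so the expectation rests on a 53-fold higher number from compound 1 to compound 3 (1.72 log units; beyond the scatter) and a 1.7-fold lower number from compound 2 to compound 3 (0.24 log units; within the scatter) from only three compounds. The step expected in this assay is none beyond the scatter, estimated as a 1.4-fold lower number from compound 3 to compound 4 (0.14 log units; within the scatter) in size. For compound 4 the estimated value is 5000 nM with an expected range from 1500 nM to 15000 nM in this read-out.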

Compound 4, half-maximal inhibitory concentration: 150 nM
For compound 4 the middle estimate is 33-fold (1.52 log units) above the measured one, and the stated range ends above it.
By their numbers in this assay, from the lowest: compounds 1 and 4 (each within the scatter of the next); then compounds 3 and 2 (each within the scatter of the next).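

In this assay, the identity of the six-membered non-aromatic ring on a saturated chain carbon, four bonds along the chain from an aromatic nitrogen, proves decisive, a point the within-scatter butyl step had not revealed: piperidin-1-yl gives large drops against both 4-butylpiperazin-1-yl (a 46-fold lower number from compound 3 to compound 4 (1.66 log units; beyond the scatter)) and piperazin-1-yl (an 80-fold lower number from compound 2 to compound 4 (1.90 log units; beyond the scatter)). Going by these compounds alone, the 1H-imidazol-1-yl group of compound 1 is not the only group compatible with a low number here, since piperidin-1-yl cannot be separated from it (a 1.2-fold higher number from compound 1 to compound 4 (0.06 log units; within the scatter)). Among these four compounds, the high numbers belong to the two piperazine compounds, whose rings hold 2 hetero atoms, but a link to a second ring nitrogen alone fails, as compound 1 goes against it with its 1H-imidazol-1-yl group.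

No accompanying measurement bears on what lies behind these large steps. On these data alone, it remains open whether morpholin-4-yl, pyrrolidin-1-yl or a dimethylamino group at the same place would fall with compound 4 or with compound 3, and whether a shorter chain would keep the piperidin-1-yl result.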